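Cyclopropyl replaces hydroxycyclohexyl on a weak adenosine ligand

The source may hold more compounds than are shown below. What is called first, only, known or untested is meant among the compounds shown, and "the series" means these compounds.

Compound 2 `OC1CCC(Nc2nc(-c3ccccc3)nc3c2nnn3Cc2ccccc2)CC1` gives 2700000 nM in an assay on isolated protein for binding affinity to adenosine receptor A1 (Bos taurus) (on this read-out higher numbers stand for weaker inhibition and lower numbers for stronger inhibition), the lower of the two numbers measured, since compound 1 `CCCCCCNc1nc(-c2ccccc2)nc2c1nnn2Cc1ccccc1` gives 13200000 nM. Among the compounds with values here, the one recorded step, a 4.9-fold lower number from compound 1 to compound 2 (0.69 log units; beyond the scatter), swapped a hexyl chain for 4-hydroxycyclohexyl. Compound 3 `c1ccc(Cn2nnc3c(NC4CC4)nc(-c4ccccc4)nc32)cc1` makes a different change: cyclopropyl in place of 4-hydroxycyclohexyl on a nitrogen on an aromatic ring. Within the data shown here, no measured step covers this exchange, so the expectation rests loosely on compound 2 alone. Compound 3 is estimated at 4000000 nM, with a range from 1000000 nM to 15000000 nM. That expected step, a 1.5-fold higher number from compound 2 to compound 3 (0.17 log units; within the scatter), would stay within the usual scatter.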

Compound 3, inhibition constant: 11000000 nM
Compound 3: the middle estimate sits 2.8-fold (0.44 log units) below what was measured, within the range that was stated.
By their numbers in this assay, from the lowest: compound 2; then compounds 3 and 1 (each within the scatter of the next).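

Going from 4-hydroxycyclohexyl to cyclopropyl on this nitrogen gives a 4.1-fold higher number from compound 2 to compound 3 (0.61 log units; beyond the scatter) and shows that the lower number of compound 2 does not extend to every non-aromatic carbon ring placed here. Cyclopropyl in place of hexyl gives a 1.2-fold lower number from compound 1 to compound 3 (0.08 log units; within the scatter) and leaves these two groups indistinguishable, so among the three compounds only 4-hydroxycyclohexyl stands apart. Nothing available explains this difference. Still open, on these data alone, is whether the hydroxyl or the six-membered ring accounts for it. A plain cyclohexyl on the same nitrogen would separate the two.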